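The source may hold more compounds than are shown below. What is called first, only, known or untested is meant among the compounds shown, and "the series" means these compounds.

In a functional assay on HCT-116 cells (Homo sapiens) for antiproliferative activity, read by MTT assay, with a stated time of 72 h (a higher number here means a weaker inhibitor, a lower number a stronger inhibitor), compound 1 `O=C(CCc1cccc2c1B(O)OC2)Nc1ccccc1` gives 350 nM, compound 2 `O=C(CCc1cccc2c1B(O)OC2)Nc1ccc(F)cc1` gives 650 nM and compound 3 `Cc1ccc(NC(=O)CCc2cccc3c2B(O)OC3)cc1` gives 4500 nM. Compound 3 is therefore the weakest of the three, with its number clearly higher than those of both the others.

Compound 4 `CC(C)(C)c1ccc(NC(=O)CCc2cccc3c2B(O)OC3)cc1` has tert-butyl in place of methyl on an aromatic carbon, para to a large group: tert-butyl in place of methyl on an aromatic carbon.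

Going by the values given here, three measured steps bear on this change, all of them made at the same place. Methyl in place of hydrogen gave a 13-fold higher number from compound 1 to compound 3 (1.11 log units; beyond the scatter), a large step. Fluoro in place of hydrogen gave a 1.9-fold higher number from compound 1 to compound 2 (0.27 log units; within the scatter), and methyl in place of fluoro gave a 6.9-fold higher number from compound 2 to compound 3 (0.84 log units; beyond the scatter), a modest step. None of these steps involves tert-butyl, so the data offer no direct measure of it. The closest guide is the rise seen with methyl, a 13-fold higher number from compound 1 to compound 3 (1.11 log units; beyond the scatter), which points upward in this assay. A further rise is therefore expected, but only a small one that may not exceed the scatter. The expected change is a 1.6-fold higher number from compound 3 to compound 4 (0.19 log units; within the scatter). Compound 4 is estimated at 7000 nM, with an expected range from 2000 nM to 25000 nM.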

Compound 4, half-maximal inhibitory concentration: 19000 nM
For compound 4 the middle estimate is 2.7-fold (0.43 log units) below the measured one; the range from low to high includes it.
By their numbers in this assay, from the lowest: compounds 1 and 2 (each within the scatter of the next); then compound 3; then compound 4.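

With tert-butyl, the upward trend that methyl began at this position continues in this assay (a 4.2-fold higher number from compound 3 to compound 4 (0.63 log units; beyond the scatter)), a modest step but one beyond the scatter, so replacing methyl with a bigger alkyl group here brings a further measurable loss rather than a levelling off. The distance from the other two compounds is much greater (a 54-fold higher number from compound 1 to compound 4 (1.73 log units; beyond the scatter); a 29-fold higher number from compound 2 to compound 4 (1.47 log units; beyond the scatter)), and both of these steps are large, which places tert-butyl well away from hydrogen and fluoro, themselves within the scatter of each other. Among these four compounds, the two alkyl groups are the ones that raise the number beyond the scatter from compound 1, tert-butyl more so than methyl, but no measurement shown here gives a reason for this rise.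

What the compounds leave open is whether this rise is confined to alkyl groups or also appears with groups of other kinds at this position, such as methoxy, an amine or a carboxylic acid. As far as these compounds go, it is also open whether an ethyl or isopropyl group would fall between methyl and tert-butyl, and whether the same changes would have a similar effect elsewhere on this ring.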